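The compounds below may be only part of what the source reports. "The series", "measured", "known", "first", "only" and "open" are said of these compounds alone.

Compound 1: `COc1cc(N)c(Cl)cc1NC(=O)C1CCN(C2CCCC2)CC1` — in a functional assay on the whole organism for antagonist activity, with Mus musculus as the target (a higher number here means that more compound is needed for the effect, a lower number that less compound is needed), compound 1 gives > 10 mg/kg, which is a limit of the assay and not a number.
Compound 2: `COc1cc(N)c(Cl)cc1NC(=O)C1CCN(Cc2cccc(C#N)c2)CC1` — in this assay compound 2 gives > 4 mg/kg, likewise a limit and not a number.

Among the measured compounds shown here, compound 2 thus stands only at a limit, as does compound 1; the step that the two limits leave unreadable from compound 1 to compound 2 therefore cannot be read in either size or direction, and it is the only measured step in this set. Compound 3 is `CCC(CC)CN1CCC(C(=O)Nc2cc(Cl)c(N)cc2OC)CC1`. Its change from compound 2 is pentan-3-yl in place of 3-cyanophenyl on a saturated chain carbon bound to an amine nitrogen in a ring. For the measured compounds named here, no measured step bears on this change with a readable size, so no direction beyond the scatter can be expected. The step from compound 2 to compound 3 is therefore expected to be about a step that the limit leaves unreadable from compound 2 to compound 3. For compound 3 in this assay the estimate is 8 mg/kg, with a range from 2.5 mg/kg to 30 mg/kg, and a further limit is expected to be the most likely outcome.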

Compound 3, dose for half-maximal effect: > 10 mg/kg
Compound 3 was reported as a limit; the forecaster's own chance of this, stated with the estimate: 65%; middle value at least 1.2-fold (0.09 log units) away from the limit.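

Compound 3 gives > 10 mg/kg in this assay, which is a limit and not a number. With compound 1 and compound 2 also at limits, neither step to compound 3 can be read. The compounds shown leave open whether these groups on the amine nitrogen in a ring differ at all in the dose needed.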